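The source may hold more compounds than are shown below. What is called first, only, known or untested is meant among the compounds shown, and "the series" means these compounds.

Among the measured compounds shown here, in a functional assay on BaF3 cells (Mus musculus) for inhibition, read by MTT assay, with a stated time of 3 days (on this read-out higher numbers stand for weaker inhibition of growth and lower numbers for stronger inhibition of growth), compound 3 `CC(C)(C)c1cc(NC(=O)Nc2ccc(Nc3ncnc4c3OCCN4)c(F)c2)no1` gives 10000 nM and this is the only true number so far. In this assay compound 1 `O=C(Nc1ccc(Cl)cc1)Nc1ccc(Nc2ncnc3c2OCCN3)cc1` reads > 10000 nM and this is a limit of the assay, not a number. Compound 2 `Cc1cc(C)cc(NC(=O)Nc2ccc(Nc3ncnc4c3OCCN4)cc2)c1` reads > 10000 nM and this too is a limit. For the measured compounds named here, the series so far is therefore framed by the limit of > 10000 nM in this assay, at which 2 of the 3 values shown sit, and offers little spread to work with. Compound 4 `COc1cc(NC(=O)Nc2cc(C(C)(C)C)on2)ccc1Nc1ncnc2c1OCCN2` carries methoxy in place of fluoro on an aromatic carbon and its measurement is still to come. Going by the values given here, the only measured step is a step that the two limits leave unreadable from compound 1 to compound 2 and it involves a different place in the molecule, so it gives no size or direction to carry over. Among the compounds with values here, no measured step bears on the swap itself. The expected result is therefore no change beyond the scatter, with an estimated no change at the digits printed from compound 3 to compound 4 (within the scatter) as the working figure. Compound 4 is estimated at 10000 nM with an expected range from 5000 nM to 20000 nM and a report of only a limit would be no surprise.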

Compound 4, concentration for 50% growth inhibition: > 10000 nM
Compound 4: no number, only a limit; the forecaster's own chance of this, stated with the estimate: 65%; the middle value lies on the limit itself.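

In this assay, methoxy in place of fluoro on an aromatic carbon, ortho to a large group and meta to a large group, gives a number no lower from compound 3 to compound 4 (the limit leaves the size open). Unlike the earlier step among the compounds, this one has a direction though no size: the change brings no stronger inhibition of growth than compound 3 shows. Compound 3 therefore remains the only compound with a true number, and the series stays pressed against the edge of what the assay can read: the limit of > 10000 nM in this assay, at which 3 of the 4 values shown sit.

As far as these compounds go, how far compound 4 really lies from compound 3 stays open, as the limit hides its true value. Also open, from the compounds shown here alone, is whether an amine or a carboxylic acid on this same aromatic carbon would give a number clearly lower than that of compound 3.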